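A few compounds are considered here, and "the series" means these few. Any claim that something is new, unique, unknown or untested is made for them only; others in the source may bear on it.

Measured compounds in a functional assay on the whole organism (strain Wistar) for inhibition, with Rattus norvegicus as the target, read by paw edema, with stated times of 30 min and 2 h, at a dose of 20 mg/kg; on this read-out higher numbers stand for more inhibition at the one dose given (going by the name of the read-out) and lower numbers for less inhibition:
compound 1 `CCOC(=O)C1=C(C)NC(C)=C(C(=O)OCC)C1c1ccc(OCC(=O)NNC(=O)c2ccc(C)cc2)cc1` gives 46.7%
compound 2 `CCOC(=O)C1=C(C)NC(C)=C(C(=O)OCC)C1c1ccc(OCC(=O)NNC(=O)c2ccccc2)cc1` gives 44.5%
compound 3 `CCOC(=O)C1=C(C)NC(C)=C(C(=O)OCC)C1c1ccc(OCC(=O)NNC(=O)c2cccs2)cc1` gives 62.2%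

Compound 1 stands second highest of the three; its nearest neighbour is compound 2, a number 2.2 percentage points lower from compound 1 to compound 2 (within the scatter), and its furthest is compound 3, a number 15.5 percentage points higher from compound 1 to compound 3 (beyond the scatter). Compound 4 `CCOC(=O)C1=C(C)NC(C)=C(C(=O)OCC)C1c1ccc(OCC(=O)n2nc(C)cc2C)cc1` differs from compound 1 in one place: 3,5-dimethyl-1H-pyrazol-1-yl in place of (((4-methylphenyl)carbonyl)amino)amino on a carbonyl carbon. The measured steps only exchange the aryl group on the carbonyl carbon, as in a number 15.5 percentage points higher from compound 1 to compound 3 (beyond the scatter) and a number 17.7 percentage points higher from compound 2 to compound 3 (beyond the scatter), or swap a methyl for hydrogen, as in a number 2.2 percentage points lower from compound 1 to compound 2 (within the scatter). None of them removes the (((4-methylphenyl)carbonyl)amino)amino group, so they give no direct guide to this change and no direction beyond the scatter can be expected with confidence. Compound 4 is estimated at 45%, with a range from 25% to 65%. That estimate means only a small step of a number 1.7 percentage points lower from compound 1 to compound 4 (within the scatter).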

Compound 4, a percentage reported as inhibition, in the whole organism at one dose (the size of the read-out at that dose, not a potency): 46.1%
Compound 4: middle estimate off by 1.1 percentage points, on the low side, and the stated range covers the measured number.
By their numbers in this assay, from the lowest: compounds 2, 4 and 1 (each within the scatter of the next); then compound 3.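

In this assay, the 3,5-dimethyl-1H-pyrazol-1-yl group on the carbonyl carbon stands level with both benzoyl-bearing chains, with a number 0.6 percentage points lower from compound 1 to compound 4 (within the scatter) and a number 1.6 percentage points higher from compound 2 to compound 4 (within the scatter), so the hydrazide-type link is not needed to hold that level at this position. It does not match the thiophene-bearing chain, however, with a number 16.1 percentage points lower from compound 3 to compound 4 (beyond the scatter). Nothing here offers an explanation for this result. The compounds shown leave open whether the two methyl groups on the pyrazole matter, and whether a simple amine or a carboxylic acid on this carbonyl carbon would give a similar number.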